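Shortening the Amine Linker of a Phenoxyalkylamine

The compounds below may be only part of what the source reports. "The series", "measured", "known", "first", "only" and "open" are said of these compounds alone.

Compound 1, with the structure `CNCCCOc1ccccc1`, is the weaker of the two measured compounds. In a functional assay for agonist activity at 5-hydroxytryptamine receptor 1B (Homo sapiens) (a lower number here means a stronger inhibitor, a higher number a weaker inhibitor), compound 1 gives 3450 nM, the highest number of the two. Among the measured compounds shown here, compound 2, `CC(C)NCCOc1cccc2ccccc12`, gives 120 nM in this assay, a markedly lower number, but it differs from compound 1 in several places at once, so no single step between them can be read.

Compound 3, `CNCCOc1ccccc1`, has not yet been measured. It differs from compound 1 by methylamino in place of (methylamino)methyl on a saturated chain carbon, two bonds along the chain from an oxygen on an aromatic ring. In simpler terms, the part carrying the amine is cut by one link, so that it reads 2-(methylamino)ethyl to (methylamino)methyl.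

For the measured compounds named here, no pair of measured compounds shows this change alone, so its effect must be judged without a direct precedent. Compound 2 carries its amine on the shorter arrangement, yet its other differences make it an uncertain guide. A moderate shift is expected, toward a lower number, though a result within the scatter would not surprise. For compound 3 the estimated step from compound 1 is a 1.9-fold lower number from compound 1 to compound 3 (0.28 log units; within the scatter). Compound 3 is therefore expected to give about 1800 nM, most likely between 500 nM and 6000 nM.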

Compound 3, inhibition constant: 5960 nM
Compound 3: the middle estimate sits 3.3-fold (0.52 log units) below what was measured; measured number inside the range.
By their numbers in this assay, from the lowest: compound 2; then compounds 1 and 3 (each within the scatter of the next).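

In this assay, removing one link from the chain that carries the amine, so that 2-(methylamino)ethyl becomes (methylamino)methyl, gives a 1.7-fold higher number from compound 1 to compound 3 (0.24 log units; within the scatter). Among the compounds shown here, this is the first single change that can be read on its own, and it shows that at this place on the chain, the loss of that one link leaves the two compounds within the usual scatter of repeated measurements, so compound 1 and compound 3 cannot be told apart in this assay. No supporting measurement is available that bears on this result or could account for it.

The steps that involve compound 2 cannot be read, since it differs from compound 1 and compound 3 in more than one place, and the much lower number it gives therefore cannot be assigned to any single part of its structure. Also open, on these data alone, is whether a longer chain such as 4-(methylamino)butyl, or dimethylamino in place of methylamino, would move the number beyond the scatter on the core of compound 1.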